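A Nitro Group Enters Where Chlorine Leaves

A few compounds are considered here, and "the series" means these few. Any claim that something is new, unique, unknown or untested is made for them only; others in the source may bear on it.

Compound 2 `O=c1ccc2cc(OCc3cc(-c4cccc5ccccc45)no3)ccc2o1`: 41600 nM
Compound 3 `O=c1ccc2cc(OCc3cc(-c4cccc(Cl)c4)no3)ccc2o1`: 50600 nM

Two compounds carry a number in a functional assay on HL-60 cells (Homo sapiens) for cytotoxicity, read by MTT assay, with a stated time of 48 h; on this read-out lower numbers stand for stronger inhibition and higher numbers for weaker inhibition. Compound 2 gives 41600 nM, and compound 3 gives 50600 nM; these two values sit within the usual scatter of each other, so neither can be called the stronger. Compound 1 `C#CCOc1ccc2oc(=O)ccc2c1`, a smaller relative, stands in this assay as "not determined" (no result reported). Compound 4 `O=c1ccc2cc(OCc3cc(-c4ccc([N+](=O)[O-])cc4)no3)ccc2o1` is the next member: 4-nitrophenyl in place of 3-chlorophenyl on an aromatic carbon. No step between measured compounds shares this change, so nothing shown gives its direction or size. Compound 2 and compound 3 swap one aromatic group for another yet land close together. The step of a 1.2-fold lower number from compound 3 to compound 4 (0.08 log units; within the scatter) is therefore expected to stay within the scatter. Compound 4 is estimated at 42000 nM, with a range from 15000 nM to 120000 nM.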

Compound 4, half-maximal inhibitory concentration: 55800 nM
Beside the measured number, compound 4's estimate is 1.3-fold (0.12 log units) below it, within the range that was stated.
By their numbers in this assay, from the lowest: compounds 2, 3 and 4 (each within the scatter of the next).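

In this assay the swap gives a 1.1-fold higher number from compound 3 to compound 4 (0.04 log units; within the scatter), so 4-nitrophenyl and 3-chlorophenyl cannot be told apart at this place on the five-membered aromatic ring. The entering group carries hydrogen-bond acceptors and the leaving group has none, yet this difference in structure comes with no difference beyond the scatter. No measurement shown bears on why this is so. From the compounds shown here alone, whether an amine or a carboxylic acid at this place would move the number beyond the scatter remains open.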